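Triazole N-aryl variation in a diaryl urea series

A few compounds are considered here, and "the series" means these few. Any claim that something is new, unique, unknown or untested is made for them only; others in the source may bear on it.

Measured compounds:
compound 1, `CCc1ccc(-n2cc(COc3cccc(NC(=O)Nc4ccc(Cl)c(C(F)(F)F)c4)c3)nn2)cc1`, 1950 nM
compound 2, `O=C(Nc1cccc(OCc2cn(-c3ccccc3F)nn2)c1)Nc1ccc(Cl)c(C(F)(F)F)c1`, 1520 nM

Of the compounds shown here, two have been tested in a functional assay on HepG2 cells (Homo sapiens) for inhibition, read by MTT assay, with a stated time of 72 h; on this read-out higher numbers stand for weaker inhibition and lower numbers for stronger inhibition. Compound 1 gives 1950 nM and compound 2 gives 1520 nM. Compound 2 holds the lowest of the two numbers, but the step of a 1.3-fold lower number from compound 1 to compound 2 (0.11 log units; within the scatter) lies within the scatter, so the two cannot be ordered.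

Compound 3, `O=C(Nc1cccc(OCc2cn(-c3ccc(Cl)cc3)nn2)c1)Nc1ccc(Cl)c(C(F)(F)F)c1`, has not yet been measured. It differs from compound 2 by the change (4-chlorophenyl in place of 2-fluorophenyl on an aromatic nitrogen). For the measured compounds named here, the only measured step that bears on this position, a 1.3-fold lower number from compound 1 to compound 2 (0.11 log units; within the scatter), exchanged one aryl group on the aromatic nitrogen for another and did not move the number beyond the scatter. On that basis, no step beyond the scatter is expected for a 1.1-fold higher number from compound 2 to compound 3 (0.05 log units; within the scatter). Compound 3 is therefore estimated at 1700 nM, with a range from 700 nM to 4000 nM.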

Compound 3, half-maximal inhibitory concentration: 2490 nM
Compound 3: the middle estimate sits 1.5-fold (0.17 log units) below what was measured; the range from low to high includes it.
By their numbers in this assay, from the lowest: compounds 2, 1 and 3 (each within the scatter of the next).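

In this assay, the exchange of 2-fluorophenyl for 4-chlorophenyl on the aromatic nitrogen gives a 1.6-fold higher number from compound 2 to compound 3 (0.21 log units; within the scatter) and stays within the scatter, while chloro in place of ethyl on an aromatic carbon gives a 1.3-fold higher number from compound 1 to compound 3 (0.11 log units; within the scatter) and also stays within it. With 4-ethylphenyl, 2-fluorophenyl and 4-chlorophenyl now compared on this nitrogen, every step among compound 1, compound 2 and compound 3 lies within the scatter, so these three aryl groups cannot be ordered. No evidence is available that would explain these numbers.

Going by these compounds, it remains open whether an aryl group carrying an amine or a carboxylic acid would give a step beyond the scatter at this nitrogen. The same question stands for a longer alkyl chain in place of the aryl group.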